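Shifting the Piperazine on a Shared Core

The source may hold more compounds than are shown below. What is called first, only, known or untested is meant among the compounds shown, and "the series" means these compounds.

In a physicochemical assay for solubility, read by HPLC, using the shake flask method, in phosphate buffer, with a stated time of 20 h, at pH 6.5 (a lower number here means a less soluble compound, a higher number a more soluble compound), compound 1 (`CN1CCN(C2CCN(c3nccc4[nH]c(-c5ccc(F)c(F)c5)nc34)CC2)CC1`) gives 130000 nM and compound 2 (`CN1CCN(C2CCN(c3nccc4[nH]c(-c5cccc(OC(F)(F)F)c5)nc34)CC2)CC1`) gives 190000 nM while compound 3 (`CN1CCN(C2CCN(c3nccc4[nH]c(-c5cc(F)cc(F)c5)nc34)CC2)CC1`) gives 200000 nM on the same core. Compound 3 therefore stands level with the other two, within the scatter of repeated measurements.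

Compound 4 (`Fc1cc(F)cc(-c2nc3c(N4CCC(CN5CCNCC5)CC4)nccc3[nH]2)c1`) has the same atoms as compound 3, joined differently, with (piperazin-1-yl)methyl in place of 4-methylpiperazin-1-yl on a saturated ring carbon.

Three steps have been measured: a 1.5-fold higher number from compound 1 to compound 2 (0.16 log units; within the scatter) and a 1.5-fold higher number from compound 1 to compound 3 (0.19 log units; within the scatter) and also a 1.1-fold higher number from compound 2 to compound 3 (0.02 log units; within the scatter) for swaps of the phenyl group alone, each within the scatter. Going by the values given here, they bear on this change only indirectly, since none touches the saturated ring carbon, so the data hold no direct precedent for it. With compound 3 at 200000 nM as the starting point, no step beyond the scatter is expected. The expected change is a 1.1-fold higher number from compound 3 to compound 4 (0.02 log units; within the scatter) in this assay as the working estimate. The estimate for compound 4 is 210000 nM with an expected range from 90000 nM to 480000 nM for the coming measurement.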

Compound 4, solubility: 190000 nM
For compound 4 the middle estimate is 1.1-fold (0.04 log units) above the measured one; the range from low to high includes it.
By their numbers in this assay, from the lowest: compounds 1, 2, 4 and 3 (each within the scatter of the next).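

In this assay the swap of 4-methylpiperazin-1-yl for (piperazin-1-yl)methyl on a saturated ring carbon gives a 1.1-fold lower number from compound 3 to compound 4 (0.02 log units; within the scatter) and is the first step shown at this position, since the earlier steps touched only the phenyl group. The two groups hold the same atoms, joined differently, and the entering group carries 1 hydrogen-bond donor where the leaving group has 0, yet the two compounds stand level within the scatter. No measurement here offers an explanation for this result.

Going by these compounds, this single pair carries 3,5-difluorophenyl, so it remains open whether the same swap would stay within the scatter with 3,4-difluorophenyl or 3-(trifluoromethoxy)phenyl on the shared core. Also open, on these data alone, is how a carboxylic acid or a morpholine on a longer chain would read at this saturated ring carbon.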